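Fluorine for chlorine on a growth inhibitor

This account rests on a few compounds, and the source may have more. Where it says the series, first, only, none or still open, it means among the compounds named here.

In a functional assay on HT-29 cells (Homo sapiens) (a higher number here means a weaker inhibitor of growth, a lower number a stronger inhibitor of growth), compound 1 (`O=S(=O)(/C=C/c1ccc(F)cc1)Cc1ccc(Nc2ncnc3ccccc23)cc1`) gives 1000 nM as its reading. Compound 2 (`N#Cc1ccc(/C=C/S(=O)(=O)Cc2ccc(Nc3ncnc4ccccc34)cc2)cc1`) gives > 100000 nM as a limit of the assay and not a number. Among the compounds with values here, compound 3 (`O=S(=O)(/C=C/c1ccc(Cl)cc1Cl)Cc1ccc(Nc2ncnc3ccccc23)cc1`) gives 24000 nM and so holds the higher of the two exact numbers so far.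

Compound 4 (`O=S(=O)(/C=C/c1ccc(F)cc1F)Cc1ccc(Nc2ncnc3ccccc23)cc1`) awaits measurement. It differs from compound 3 by one swap (2,4-difluorophenyl in place of 2,4-dichlorophenyl on a double-bonded chain carbon bound to a double-bonded chain carbon), with 2,4-difluorophenyl in place of 2,4-dichlorophenyl. Within the data shown here, two measured steps bear on this. The large step of a 24-fold higher number from compound 1 to compound 3 (1.38 log units; beyond the scatter) came with 2,4-dichlorophenyl in place of 4-fluorophenyl, and the large step of an at least 100-fold higher number from compound 1 to compound 2 (2.00 log units; beyond the scatter) came with cyano in place of fluoro. Among the measured compounds shown here, compound 1, the only fluoro compound measured, sits lowest of the three. For the measured compounds named here, compound 4 also carries fluoro, so a move back toward compound 1 is expected, though no measured compound has 2,4-difluorophenyl. The expected change is a sizeable drop (a 6.0-fold lower number from compound 3 to compound 4 (0.78 log units; beyond the scatter)). Compound 4 is estimated at 4000 nM (expected range 800 nM to 20000 nM).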

Compound 4, concentration for 50% growth inhibition: > 100000 nM
Compound 4: only a limit was reported (the forecaster's own chance of this, stated with the estimate: 8%); middle value at least 25-fold (1.39 log units) away from the limit.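

In this assay, fluoro in place of hydrogen on an aromatic carbon proves costly, with an at least 100-fold higher number from compound 1 to compound 4 (2.00 log units; beyond the scatter), so one added fluoro is enough to lose most of the growth inhibition seen with compound 1. Fluoro on this ring therefore does not bring the number down by itself, as 2,4-difluorophenyl in place of 2,4-dichlorophenyl gives an at least 4.1-fold higher number from compound 3 to compound 4 (0.61 log units; beyond the scatter). Compound 4 carries a limit of the assay and not a number, as does compound 2, so the step between these two cannot be read: the limit of > 100000 nM in this assay, at which 2 of the 4 values shown sit.

The compounds shown leave open what a methoxy group, an amine or a carboxylic acid would do on this ring in place of fluoro. Also open are what a plain phenyl ring would give and why one added fluoro matters so much.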